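Changing one amide group on a compound at the limit

The source may hold more compounds than are shown below. What is called first, only, known or untested is meant among the compounds shown, and "the series" means these compounds.

In a physicochemical assay for solubility, measured as kinetic solubility (a lower number here means a less soluble compound, a higher number a more soluble compound), compound 1 `COc1ccc(S(=O)(=O)Nc2ccc(Cn3cc4c(n3)CN(C(=O)c3cccc(Cl)c3)C4)cc2)cc1` gives 19000 nM. Compound 2 `COc1ccc(S(=O)(=O)Nc2ccc(CN3CCN(C(=O)C4CCCN(C)C4)CC3)cc2)cc1` gives >= 526000 nM, and this is a limit of the assay, not a number. Among the compounds with values here, it is the only information on where compound 2 stands.

Compound 3 `COc1ccc(S(=O)(=O)Nc2ccc(CN3CCN(C(=O)Cn4cccnc4=O)CC3)cc2)cc1` differs from compound 2 on a carbonyl carbon: a group of 8 heavy atoms (5 carbon, 2 nitrogen, 1 oxygen; one six-membered aromatic ring with 2 hetero atoms) in place of a group of 7 heavy atoms (6 carbon, 1 nitrogen; one six-membered non-aromatic ring with 1 hetero atom), on a carbonyl carbon. The 1-methylpiperidin-3-yl group leaves, and a group with a six-membered aromatic ring with 2 hetero atoms enters.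

Within the data shown here, no measured pair shows this kind of change, so any expectation here is loose. A downward move beyond the usual scatter is expected, estimated as an at least 2.9-fold lower number from compound 2 to compound 3 (0.46 log units; beyond the scatter). Among the measured compounds shown here, compound 1 at 19000 nM is the only true number available, and it serves as a rough guide for the lower end. The expected value for compound 3 is 180000 nM, with an estimated range of 60000 nM to 500000 nM.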

Compound 3, solubility: >= 336000 nM
Compound 3 was reported as a limit; the forecaster's own chance of this, stated with the estimate: 30%; middle value at least 1.8-fold (0.27 log units) away from the limit.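

In this assay compound 2 gives the limit >= 526000 nM. Compound 3 also gives a limit, >= 336000 nM. Within the data shown here, with only these two limits, no step between compound 2 and compound 3 can be read. As far as these compounds go, whether replacing the 1-methylpiperidin-3-yl group changes the read-out at all, and in which direction, stays open.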